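Indole amines as monoamine oxidase A inhibitors: extending the amine

A few compounds are considered here, and "the series" means these few. Any claim that something is new, unique, unknown or untested is made for them only; others in the source may bear on it.

Measured so far:
compound 1 `CC#CCN(C)Cc1cc2cc(O)ccc2n1C` gives 5.75 nM in an assay on isolated protein for inhibition of Amine oxidase [flavin-containing] A (Rattus norvegicus); a higher number here means a weaker inhibitor, a lower number a stronger inhibitor;
compound 2 `C#CCNCc1cc2cc(OC)ccc2n1C` gives 0.813 nM in this assay.

Compound 2 holds the lower of the two numbers; compound 1 sits higher by a margin beyond the scatter. Compound 3 `CC#CCN(C)Cc1cc2cc(OC)ccc2n1C` carries (but-2-yn-1-yl)(methyl)amino in place of propargylamino on a saturated chain carbon bound to an aromatic carbon. Compound 1 bears this same amine together with a different ring substituent, so its number offers a partial pointer. Among the compounds with values here, no measured pair isolates this change. For compound 3 the expected step of a 3.7-fold higher number from compound 2 to compound 3 (0.57 log units; beyond the scatter) is toward a weaker inhibitor, modest in size. Compound 3 is estimated at 3 nM, within 0.8 nM to 12 nM.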

Compound 3, inhibition constant: 1.41 nM
Beside the measured number, compound 3's estimate is 2.1-fold (0.33 log units) above it, and the stated range covers the measured number.
By their numbers in this assay, from the lowest: compounds 2 and 3 (each within the scatter of the next); then compound 1.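

At the amine on a saturated chain carbon bound to an aromatic carbon, (but-2-yn-1-yl)(methyl)amino in place of propargylamino gives in this assay a 1.7-fold higher number from compound 2 to compound 3 (0.24 log units; within the scatter), so this change leaves no readable difference. Within the data shown here, with that amine held constant, methyl in place of hydrogen on an oxygen on an aromatic ring gives a 4.1-fold lower number from compound 1 to compound 3 (0.61 log units; beyond the scatter), the only step here beyond the scatter. No evidence at hand explains either step.

Open, going by these compounds, is whether a longer chain on the alkyne keeps the number in this range. Also open, on these data alone, is whether an ethyl in place of that oxygen's methyl does so.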